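Pyrrolidin-1-yl to (3-fluorophenyl)amino: expected return of inhibition

The source may report more compounds than this note shows. Statements on the series, on what has been measured and on what is new or still open speak of the compounds shown alone.

Of the compounds shown here, three on the shared core have been read in a functional assay on MCF7 cells (Homo sapiens) for inhibition, read by sulforhodamine B assay; on this read-out lower numbers stand for stronger inhibition and higher numbers for weaker inhibition. Compound 1 `COc1ccccc1NC1=CC(=O)c2c(nc3n2[C@H]2OC[C@@H](O)[C@H]2OC3)C1=O` gives 6580 nM in this assay. Compound 2 `CCOc1ccccc1NC1=CC(=O)c2c(nc3n2[C@H]2OC[C@@H](O)[C@H]2OC3)C1=O` reaches only a limit of the assay, > 4000 nM. Compound 3 `O=C1C(N2CCCC2)=CC(=O)c2c1nc1n2[C@H]2OC[C@@H](O)[C@H]2OC1` likewise reaches only a limit of the assay, > 16000 nM. Compound 3 therefore sits at the limit of > 16000 nM in this assay, at which 1 of the 3 values shown sits, and stands weaker than compound 1; the only other limit shown is the limit of > 4000 nM in this assay, at which 1 of the 3 values shown sits. The step that the limit leaves unreadable from compound 1 to compound 2 cannot be sized. The step of an at least 2.4-fold higher number from compound 1 to compound 3 (0.38 log units; beyond the scatter) is readable and shows weaker inhibition once (2-methoxyphenyl)amino gives way to pyrrolidin-1-yl.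

Compound 4 `O=C1C(Nc2cccc(F)c2)=CC(=O)c2c1nc1n2[C@H]2OC[C@@H](O)[C@H]2OC1` is not yet measured. It differs from compound 3 in one place: (3-fluorophenyl)amino in place of pyrrolidin-1-yl on a double-bonded ring carbon. This change is close to a reversal of the step that separates compound 1 from compound 3, restoring an aromatic amine on the double-bonded ring carbon. A step of an at least 2.2-fold lower number from compound 3 to compound 4 (0.35 log units; beyond the scatter) toward stronger inhibition is therefore expected, bringing compound 4 back near the range of compound 1. Compound 4 is estimated at 7000 nM, with an expected range from 2500 nM to 20000 nM.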

Compound 4, half-maximal inhibitory concentration: > 4000 nM
Compound 4 was reported as a limit; the forecaster's own chance of this, stated with the estimate: 30%; the middle value lies beyond the limit too.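

In this assay compound 4 gives only a limit, > 4000 nM. Going by these compounds alone, no step to compound 4 from compound 1, compound 2 or compound 3 can be read. The compounds shown leave open how (3-fluorophenyl)amino compares with (2-methoxyphenyl)amino or pyrrolidin-1-yl on the shared core.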